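The source may report more compounds than this note shows. Statements on the series, on what has been measured and on what is new or still open speak of the compounds shown alone.

In a functional assay on A549 cells (Homo sapiens) for cytotoxicity, read by XTT assay, with a stated time of 72 h (on this read-out lower numbers stand for stronger inhibition and higher numbers for weaker inhibition), compound 1 `CN(C)C(=O)c1ccc(-c2cc(C3=CC(=O)C=CC3=O)no2)s1` gives only a limit, > 30000 nM. Compound 2 `CCCN(C)C(=O)c1ccc(-c2cc(-c3cc(OC)ccc3OC)no2)s1` also gives only a limit, > 30000 nM. Compound 3 `COc1ccc(OC)c(-c2cc(-c3ccc(C(=O)N4CCCC4)s3)on2)c1` likewise gives only a limit, > 30000 nM. The step that the two limits leave unreadable from compound 2 to compound 3 is thus unreadable, since the limit of > 30000 nM in this assay, at which 3 of the 3 values shown sit, holds every value of the series. Compound 4 `O=C1C=CC(=O)C(c2cc(-c3ccc(C(=O)N4CCC(C(F)(F)F)CC4)s3)on2)=C1` differs from compound 1 by 4-(trifluoromethyl)piperidin-1-yl in place of dimethylamino on a carbonyl carbon whose other neighbour is an aromatic carbon. The amide change between compound 2 and compound 3 bears on this but shows no readable size, so no direction can be drawn. Compound 4 is expected near 30000 nM, within 8000 nM to 120000 nM, most likely again only a limit. The estimated step is a number no higher from compound 1 to compound 4 (the limit leaves the size open).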

Compound 4, half-maximal inhibitory concentration: > 30000 nM
Compound 4: only a limit was reported; the forecaster's own chance of this, stated with the estimate: 75%; the middle value sits exactly at the limit.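

Compound 1 and compound 4 both give only a limit, so no new step can be read from this pair: the limit of > 30000 nM in this assay, at which 4 of the 4 values shown sit.

The compounds shown leave open whether any change of amide or of the group on the shared core shifts the read-out in this assay.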